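The source may report more compounds than this note shows. Statements on the series, on what has been measured and on what is new or still open speak of the compounds shown alone.

Measured so far in a functional assay on BGC-823 cells (Homo sapiens) for inhibition, read by CCK-8 assay, with a stated time of 48 h; a lower number here means a stronger inhibitor, a higher number a weaker inhibitor:
compound 1 `Clc1ccc(C2=NN(C3=NC(c4ccccc4)CS3)C(c3ccc4ccccc4c3)C2)cc1` gives 14600 nM
compound 2 `Brc1ccc(C2=NN(C3=NC(c4ccccc4)CS3)C(c3cccc4ccccc34)C2)cc1` gives 17400 nM

Compound 2 has the higher of the two numbers in this assay, but its gap to compound 1 is within the scatter, so the two values show no difference between them. Compound 3 `Clc1ccc(C2=NN(C3=NC(c4ccccc4)CS3)C(c3cccc4ccccc34)C2)cc1` differs from compound 2 by chloro in place of bromo on an aromatic carbon. Within the data shown here, no step between measured compounds isolates this change, and the two values in hand give no sign that it matters. In this assay the step from compound 2 to compound 3 is expected to stay within the scatter, with no set direction. The expected step is a 1.1-fold lower number from compound 2 to compound 3 (0.05 log units; within the scatter). Compound 3 is therefore estimated at 15500 nM, between 7000 nM and 35000 nM.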

Compound 3, half-maximal inhibitory concentration: 19600 nM
Beside the measured number, compound 3's estimate is 1.3-fold (0.10 log units) below it; the range from low to high includes it.
By their numbers in this assay, from the lowest: compounds 1, 2 and 3 (each within the scatter of the next).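

In this assay, among these compounds, the change from 4-bromophenyl to 4-chlorophenyl gives a 1.1-fold higher number from compound 2 to compound 3 (0.05 log units; within the scatter) and is the first isolated halogen exchange, with no difference between the two values. Naphthalen-1-yl in place of naphthalen-2-yl on the saturated ring carbon gives a 1.3-fold higher number from compound 1 to compound 3 (0.13 log units; within the scatter) and likewise shows no difference. No measured evidence bears on these results.

Neither position has yet been tested with anything other than these close pairs. From the compounds shown here alone, whether an amine or a carboxylic acid in place of the chloro would separate from these values remains open.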